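The source may hold more compounds than are shown below. What is called first, only, known or untested is meant among the compounds shown, and "the series" means these compounds.

In a functional assay on NCI-H460 cells (Homo sapiens) for antiproliferative activity, read by MTT assay, with a stated time of 72 h (a higher number here means a weaker inhibitor, a lower number a stronger inhibitor), compound 3 `CC(O)COc1ccc2c(Oc3ccc(Nc4nccc5[nH]cc(-c6ccc(F)cc6)c(=O)c45)cc3F)ccnc2c1` gives 3400 nM. That is level, within the scatter, with compound 1 `CC(C)(O)COc1ccc2c(Oc3ccc(Nc4nccc5[nH]cc(-c6ccc(F)cc6)c(=O)c45)cc3F)ccnc2c1` at 3200 nM, while compound 2 `O=c1c(-c2ccc(F)cc2)c[nH]c2ccnc(Nc3ccc(Oc4ccnc5cc(O)ccc45)c(F)c3)c12`, with hydrogen on the oxygen on the aromatic ring, gives the clearly higher 43000 nM. The change to compound 4 `COC(C)(C)COc1ccc2c(Oc3ccc(Nc4nccc5[nH]cc(-c6ccc(F)cc6)c(=O)c45)cc3F)ccnc2c1` is 1-methoxy-1-methylethyl in place of 1-hydroxyethyl on a saturated chain carbon bound to an oxygen on an aromatic ring.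

Two kinds of measured step bear on this. The step of a 1.1-fold higher number from compound 1 to compound 3 (0.03 log units; within the scatter) shows that the methyl on the chain carbon makes no difference beyond the scatter. The large steps of a 13-fold higher number from compound 1 to compound 2 (1.13 log units; beyond the scatter) and a 13-fold lower number from compound 2 to compound 3 (1.10 log units; beyond the scatter) both concern the presence or absence of the whole chain, which compound 4 keeps. For the measured compounds named here, no measured pair tests replacing the hydroxyl with methoxy, so that part of the change remains open and the range is kept wide.

The estimated step is a 1.1-fold lower number from compound 3 to compound 4 (0.05 log units; within the scatter), which means no expected shift beyond the scatter in this assay. For compound 4 the estimated value is 3000 nM, with an expected range of 1000 nM to 10000 nM.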

Compound 4, half-maximal inhibitory concentration: 4400 nM
Compound 4: the middle estimate sits 1.5-fold (0.17 log units) below what was measured; the range from low to high includes it.
By their numbers in this assay, from the lowest: compounds 1, 3 and 4 (each within the scatter of the next); then compound 2.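

In this assay, for the compounds shown here, the step of a 1.4-fold higher number from compound 1 to compound 4 (0.14 log units; within the scatter) is the first direct test of capping the chain hydroxyl as a methyl ether, and it stays within the scatter, as does a 1.3-fold higher number from compound 3 to compound 4 (0.11 log units; within the scatter). Hydrogen-bond donors in the group at this position fall from 1 in the 1-hydroxyethyl group to 0 in the 1-methoxy-1-methylethyl group without a shift beyond the scatter, and the step of a 9.8-fold lower number from compound 2 to compound 4 (0.99 log units; beyond the scatter) shows that the chain still separates from the free hydroxyl on the aromatic ring without a hydroxyl at its end. No available data explain these steps.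

Chain ends tested so far leave the number within the scatter, so it remains open whether any chain end at this position can shift it. An amine or a carboxylic acid at the chain end, or a longer chain, would test this.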